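Aryl swap on the ring nitrogen: outlook for compound 3

The compounds below may be only part of what the source reports. "The series", "measured", "known", "first", "only" and "open" are said of these compounds alone.

Going by the values given here, compound 2 `O=C(Nc1ccc(Oc2ccnc3[nH]ccc23)c(F)c1)c1cn(-c2ccc(C(F)(F)F)cc2Cl)c2ccccc2c1=O` stands alongside compound 1 `O=C(Nc1ccc(Oc2ccnc3[nH]ccc23)c(F)c1)c1cn(-c2ccc(Br)cc2F)c2ccccc2c1=O`, the only other measured compound: in a functional assay on HepG2 cells (Homo sapiens) for inhibition, read by MTT assay, with a stated time of 72 h (a lower number here means a stronger inhibitor, a higher number a weaker inhibitor), compound 2 gives 1840 nM, and in this assay compound 1 gives 2200 nM. Among the compounds with values here, the one step so far, a 1.2-fold lower number from compound 1 to compound 2 (0.08 log units; within the scatter), is flat. Compound 3 `O=C(Nc1ccc(Oc2ccnc3[nH]ccc23)c(F)c1)c1cn(-c2ccc(F)c(Cl)c2)c2ccccc2c1=O` carries 3-chloro-4-fluorophenyl in place of 2-chloro-4-(trifluoromethyl)phenyl on an aromatic nitrogen. Within the data shown here, only that flat step bears on this change, so no move beyond the scatter is expected, the estimated shift being a 1.1-fold higher number from compound 2 to compound 3 (0.04 log units; within the scatter). Compound 3 is therefore expected to give 2000 nM in this assay, within a range of 900 nM to 4500 nM.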

Compound 3, half-maximal inhibitory concentration: 3390 nM
For compound 3 the middle estimate is 1.7-fold (0.23 log units) below the measured one; low and high end bracket the measured number.
By their numbers in this assay, from the lowest: compounds 2, 1 and 3 (each within the scatter of the next).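

The step of a 1.8-fold higher number from compound 2 to compound 3 (0.27 log units; within the scatter) and the step of a 1.5-fold higher number from compound 1 to compound 3 (0.19 log units; within the scatter) both hold in this assay as the aryl group on the aromatic nitrogen changes to 3-chloro-4-fluorophenyl. Going by these compounds alone, this position now carries three halogen-bearing phenyl groups with different substitution, and no step among compounds 1, 2 and 3 leaves the scatter. No supporting data speak to why this position reads flat here. Still open, from the compounds shown here alone, is whether an amine or a carboxylic acid on this phenyl ring, or a longer alkyl chain in its place, moves the number beyond the scatter.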